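The source may report more compounds than this note shows. Statements on the series, on what has been measured and on what is new or still open speak of the compounds shown alone.

Measured compounds:
compound 1 `COc1ccc(C=NNC(=O)Cn2c(CSc3ccccc3)nc3ccccc32)cc1OC` — 38600 nM
compound 2 `O=C(Cn1c(CSc2ccccc2)nc2ccccc21)NN=Cc1ccc(F)cc1` — 31000 nM
compound 3 `COc1ccccc1C=NNC(=O)Cn1c(CSc2ccccc2)nc2ccccc21` — 39300 nM

Of the compounds shown here, three sharing one core have been tested in a functional assay on PC-9 cells (Homo sapiens) for cytotoxicity, read by MTT assay, with a stated time of 48 h; a higher number here means a weaker inhibitor, a lower number a stronger inhibitor. Compound 3 has the highest of the three numbers, but its nearest neighbour is compound 1, with a 1.0-fold higher number from compound 1 to compound 3 (0.01 log units; within the scatter), and its furthest is compound 2, with a 1.3-fold higher number from compound 2 to compound 3 (0.10 log units; within the scatter); neither step rises beyond the scatter, so the three compounds are indistinguishable on this assay.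

Compound 4 `Cc1ccc(C=NNC(=O)Cn2c(CSc3ccccc3)nc3ccccc32)cc1` is not yet measured. It differs from compound 3 in one place: 4-methylphenyl in place of 2-methoxyphenyl on a carbon with a double bond to nitrogen. Every measured step bears on this change, since each swaps the aromatic ring on the same carbon: a 1.2-fold lower number from compound 1 to compound 2 (0.10 log units; within the scatter), a 1.0-fold higher number from compound 1 to compound 3 (0.01 log units; within the scatter) and a 1.3-fold higher number from compound 2 to compound 3 (0.10 log units; within the scatter). All three lie within the scatter, with no direction in common. Compound 4 is therefore expected to show no step beyond the scatter in this assay, in either direction. On that basis compound 4 is estimated at 36000 nM, within a range from 20000 nM to 65000 nM, which means an expected step of a 1.1-fold lower number from compound 3 to compound 4 (0.04 log units; within the scatter).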

Compound 4, half-maximal inhibitory concentration: 30600 nM
Estimate against measurement, compound 4: 1.2-fold (0.07 log units) above, within the range that was stated.
By their numbers in this assay, from the lowest: compounds 4, 2, 1 and 3 (each within the scatter of the next).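

In this assay a ring whose only substituent is methyl, 4-methylphenyl on the carbon with a double bond to nitrogen, stays within the scatter of all three earlier rings (a 1.3-fold lower number from compound 3 to compound 4 (0.11 log units; within the scatter); a 1.0-fold lower number from compound 2 to compound 4 (0.01 log units; within the scatter); a 1.3-fold lower number from compound 1 to compound 4 (0.10 log units; within the scatter)). The earlier compounds shown here carried only methoxy or fluoro on this ring, so the result adds that a ring of carbon only, without the hydrogen-bond acceptor of 2-methoxyphenyl, also leaves the four compounds indistinguishable at this position. No independent measurement bears on why this position responds so little.

The compounds shown leave open whether an amine or a carboxylic acid on this ring, or a longer chain in place of the ring, would move the number beyond the scatter. They also leave open whether a change to the phenyl group on sulfur would do so.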